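The source may hold more compounds than are shown below. What is called first, only, known or untested is meant among the compounds shown, and "the series" means these compounds.

Three compounds share one core and differ only in the cap on the amine nitrogen. Compound 1 `CCCCCCCCCCCCNC(=O)[C@@H](NC(=O)c1ccccc1)[C@@H](C)O` gives 41200 nM in a functional assay on A-431 cells (Homo sapiens) for cytotoxicity, read by MTT assay, with a stated time of 48 h; a higher number here means a weaker inhibitor, a lower number a stronger inhibitor. For compound 2 `CCCCCCCCCCCCNC(=O)[C@@H](NC(=O)/C=C/c1ccccc1)[C@@H](C)O` this assay reports only a limit, > 200000 nM, at which one of the three values sits (the limit of > 200000 nM in this assay, at which 1 of the 3 values shown sits). Compound 3 `CCCCCCCCCCCCNC(=O)[C@@H](NS(=O)(=O)c1cccs1)[C@@H](C)O` gives 22000 nM in this assay. The measured steps all concern the cap: an at least 4.8-fold higher number from compound 1 to compound 2 (0.68 log units; beyond the scatter), a 1.9-fold lower number from compound 1 to compound 3 (0.27 log units; within the scatter) and an at least 9.0-fold lower number from compound 2 to compound 3 (0.95 log units; beyond the scatter). Compound 3 and compound 1 therefore stand within the scatter of each other, while compound 2 stands apart as a limit.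

Compound 4 `CCCCCCCCCCCCCCCCCCNC(=O)[C@@H](NS(=O)(=O)c1cccs1)[C@@H](C)O` differs from compound 3 by hexyl in place of hydrogen on a saturated chain carbon, ten or more bonds along the chain from an amide-type nitrogen. Among the compounds with values here, no measured step touches the chain; every one of them changes the cap, so none of them speaks to this change. Compound 4 is accordingly expected to sit close to compound 3, with a step of no change at the digits printed from compound 3 to compound 4 (within the scatter) that is not expected to exceed the scatter. The estimate for compound 4 in this assay is 22000 nM, within a range from 7000 nM to 70000 nM.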

Compound 4, half-maximal inhibitory concentration: > 200000 nM
Compound 4: a limit, no number (the forecaster's own chance of this, stated with the estimate: 10%); middle value at least 9.0-fold (0.95 log units) away from the limit.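

Within the data shown here, the chain, which no earlier step had touched, turns out not to be silent: hexyl in place of hydrogen on a saturated chain carbon, ten or more bonds along the chain from an amide-type nitrogen, gives an at least 9.0-fold higher number from compound 3 to compound 4 (0.95 log units; beyond the scatter). In this assay compound 4 reads > 200000 nM, which is a limit and not a number. With the (thiophen-2-yl)sulfonyl cap unchanged, a change in the chain alone thus reaches the same limit that compound 2 reached through a change of cap: the limit of > 200000 nM in this assay, at which 2 of the 4 values shown sit.

Going by these compounds, whether ethyl or butyl in the same place would stay within the scatter of compound 3 remains open, as does the effect of an amine or a carboxylic acid there. On these data alone, it is also open whether hexyl would act the same way on the benzoyl cap of compound 1.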